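A few compounds are considered here, and "the series" means these few. Any claim that something is new, unique, unknown or untested is made for them only; others in the source may bear on it.

Measured so far in a functional assay on MCF7 cells (Homo sapiens) for cytotoxicity, read by sulforhodamine B assay, with a stated time of 72 h; on this read-out higher numbers stand for weaker inhibition and lower numbers for stronger inhibition:
compound 1 `CCS(=O)(=O)Nc1cc(-c2ccc3ncnc(Nc4ccc(F)cc4)c3c2)cnc1OC` gives 6510 nM
compound 2 `CCS(=O)(=O)Nc1cc(-c2ccc3ncnc(Nc4ccc(OC)cc4)c3c2)cnc1OC` gives 1790 nM
compound 3 `CCS(=O)(=O)Nc1cc(-c2ccc3ncnc(Nc4ccc(F)nc4)c3c2)cnc1OC` gives 5390 nM

The three measured compounds share one core and differ only in the ring carried on a nitrogen on an aromatic ring. Compound 1 and compound 2 differ by methoxy in place of fluoro on an aromatic carbon, and that change gave a 3.6-fold lower number from compound 1 to compound 2 (0.56 log units; beyond the scatter). Compound 1 and compound 3 differ by 6-fluoropyridin-3-yl in place of 4-fluorophenyl on a nitrogen on an aromatic ring, and there a 1.2-fold lower number from compound 1 to compound 3 (0.08 log units; within the scatter). Between compound 2 and compound 3 a 3.0-fold higher number from compound 2 to compound 3 (0.48 log units; beyond the scatter).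

Compound 4 `CCS(=O)(=O)Nc1cc(-c2ccc3ncnc(Nc4ccc(OC)nc4)c3c2)cnc1OC` has not yet been measured in this assay. It differs from compound 3 by methoxy in place of fluoro on an aromatic carbon. Within the data shown here, this is the same kind of change as the one from compound 1 to compound 2, but the place is not the same: in compound 1 the fluoro sits on a six-membered aromatic ring of carbon only, para to a large group, whereas in compound 3 it sits on a six-membered aromatic ring with one nitrogen, next to the ring nitrogen, para to a large group. The difference between compound 1 and compound 3 is the one given by 6-fluoropyridin-3-yl in place of 4-fluorophenyl on a nitrogen on an aromatic ring, and in this assay it moved the number little.

The expectation for compound 4 rests on one measured instance of this kind of change, namely a 3.6-fold lower number from compound 1 to compound 2 (0.56 log units; beyond the scatter). Since the place differs, the estimate carries a wide range. Compound 4 is therefore expected to give about 1800 nM in this assay, estimated to lie between 700 nM and 5000 nM. For compound 4 this means an expected step of a 3.0-fold lower number from compound 3 to compound 4 (0.48 log units; beyond the scatter).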

Compound 4, half-maximal inhibitory concentration: 3770 nM
Estimate against measurement, compound 4: 2.1-fold (0.32 log units) below, and the stated range covers the measured number.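

In this assay, among these compounds, methoxy in place of fluoro on the ring with one nitrogen gave a 1.4-fold lower number from compound 3 to compound 4 (0.16 log units; within the scatter), and set beside the same change on the carbon-only ring, the two steps cannot be told apart: the same change on two cores in this assay, a 3.6-fold lower number (0.56 log units; beyond the scatter) from compound 1 to compound 2 and a 1.4-fold lower number (0.16 log units; within the scatter) from compound 3 to compound 4, 2.5-fold (0.41 log units) apart, within the scatter of two such steps This shows no measured difference between the two cores for this change, but it does not show that the change carries over in full, since only one of the two steps lies beyond the scatter and each core offers a single pair. With methoxy held in place, 6-methoxypyridin-3-yl in place of 4-methoxyphenyl gave a 2.1-fold higher number from compound 2 to compound 4 (0.32 log units; beyond the scatter), while 6-methoxypyridin-3-yl in place of 4-fluorophenyl gave a 1.7-fold lower number from compound 1 to compound 4 (0.24 log units; within the scatter), so the ring swap is resolved from the scatter only in the first of these two comparisons.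

The compounds shown carry only fluoro or methoxy on the ring attached through the nitrogen, so it remains open whether an amine, a nitrile or a longer chain such as ethoxy in that place would behave alike on both rings. Going by these compounds, the ethanesulfonamide and the methoxy on the other side of the shared core stay the same throughout, and how changes there would combine with these steps also remains open.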